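Swapping the sulfonyl aryl group on a shared core

The compounds below may be only part of what the source reports. "The series", "measured", "known", "first", "only" and "open" are said of these compounds alone.

Of the compounds shown here, three built on one shared core have been measured in an assay on HeLa cells for displacement of a labelled ligand from 5-hydroxytryptamine receptor 6 (Homo sapiens); a higher number here means a weaker inhibitor, a lower number a stronger inhibitor. Compound 1 `CC(C)c1ccc(S(=O)(=O)n2cc(N3CCN(C)CC3)c3ccc(Cl)cc32)cc1` gives 55.3 nM. Compound 2 `CCN1CCN(c2cn(S(=O)(=O)c3ccc(C(C)C)cc3)c3ccc(Cl)cc23)CC1` gives 30.5 nM. Compound 3 `CN1CCN(c2cn(S(=O)(=O)c3ccccc3Br)c3cc(Cl)ccc23)CC1` gives 30.2 nM.

Compound 3 differs from compound 1 in one place: 2-bromophenyl in place of 4-isopropylphenyl on a sulfonyl sulfur. This exchange made a step of a 1.8-fold lower number from compound 1 to compound 3 (0.26 log units; within the scatter), so the two numbers are not separated beyond the usual noise of the measurement.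

Compound 2 and compound 1 differ in their cores, and the difference between the two cores is not broken down here. Their two values fall within the scatter of each other, so nothing can be said about an order between them.

Compound 4 `CCN1CCN(c2cn(S(=O)(=O)c3ccccc3Br)c3ccc(Cl)cc23)CC1` has not yet been measured in this assay. It stands to compound 2 exactly as compound 3 stands to compound 1: 2-bromophenyl in place of 4-isopropylphenyl on a sulfonyl sulfur. The surroundings of the change are the same in both pairs, so this is the same change made on a second core.

Since the earlier instance of this change gave a step of a 1.8-fold lower number from compound 1 to compound 3 (0.26 log units; within the scatter), a step of similar size is expected here, namely a 1.7-fold lower number from compound 2 to compound 4 (0.23 log units; within the scatter). Starting from compound 2 at 30.5 nM, compound 4 is therefore estimated to give about 18 nM, most likely between 8 nM and 40 nM.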

Compound 4, inhibition constant: 20.3 nM
The estimate for compound 4 lay 1.1-fold (0.05 log units) below the measured number; low and high end bracket the measured number.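

On the core of compound 2, putting 2-bromophenyl in place of 4-isopropylphenyl on the sulfonyl sulfur gave, in this assay, a 1.5-fold lower number from compound 2 to compound 4 (0.18 log units; within the scatter), so this pair of numbers cannot be told apart from ordinary repeat measurements. Set beside the earlier instance, the change looks the same on the two cores, with no sign that the core alters what it does: the same change on two cores in this assay, a 1.8-fold lower number (0.26 log units; within the scatter) from compound 1 to compound 3 and a 1.5-fold lower number (0.18 log units; within the scatter) from compound 2 to compound 4, 1.2-fold (0.09 log units) apart, within the scatter of two such steps This agreement has limited weight, since each step is itself within the scatter: it shows that the exchange made no large difference on either core, but not that it truly strengthens binding, and two cores say nothing firm about any further core in this series.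

The compounds shown leave open whether a group less like these two, such as a phenyl ring carrying an amine or a carboxylic acid on the sulfonyl sulfur, would produce a step large enough to stand clear of the scatter. They also leave open what a longer chain in place of the ethyl group of compound 2 and compound 4 would do to the number, and whether the exchange would still carry over on such a compound.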